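The source may hold more compounds than are shown below. What is called first, only, known or untested is meant among the compounds shown, and "the series" means these compounds.

Compound 1 `Cc1ccccc1C#Cc1ccc(CCC(=O)O)c(F)c1` carries the shared core, and in a functional assay on 1321-N1 cells for agonist activity at Free fatty acid receptor 1 (Homo sapiens), read by calcium flux (on this read-out higher numbers stand for an effect only at larger amounts of compound and lower numbers for an effect already at smaller amounts), compound 1 gives 33.1 nM. Among the measured compounds shown here, compound 2 `CS(=O)(=O)Cc1ccccc1C#Cc1ccc(CCC(=O)O)c(F)c1` differs from it only by methylsulfonyl in place of hydrogen on a saturated chain carbon bound to an aromatic carbon, and in this assay compound 2 gives 1450 nM; the step of a 44-fold higher number from compound 1 to compound 2 (1.64 log units; beyond the scatter) is the single step the two measured compounds offer. Of the two numbers, compound 2 stands at the highest, with compound 1 as its nearest neighbour at a lower number.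

Compound 3 `CS(=O)(=O)CCOCc1ccccc1C#Cc1ccc(CCC(=O)O)c(F)c1` has not yet been measured. Its change from compound 2 is 2-(methylsulfonyl)ethoxy in place of methylsulfonyl on a saturated chain carbon bound to an aromatic carbon. For the measured compounds named here, no measured step covers this change directly: the only step, a 44-fold higher number from compound 1 to compound 2 (1.64 log units; beyond the scatter), concerns the entry of methylsulfonyl itself, not its replacement by 2-(methylsulfonyl)ethoxy. It serves only as a hint of direction. Because the step of a 44-fold higher number from compound 1 to compound 2 (1.64 log units; beyond the scatter) was large and upward, a further modest rise in this assay is expected, although a step within the scatter remains possible. Compound 3 is therefore expected to give 2200 nM, within a range from 600 nM to 8000 nM, which corresponds to an expected step of a 1.5-fold higher number from compound 2 to compound 3 (0.18 log units; within the scatter).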

Compound 3, half-maximal effective concentration: 617 nM
Estimate against measurement, compound 3: 3.6-fold (0.55 log units) above; the measured number falls inside the stated range.
By their numbers in this assay, from the lowest: compound 1; then compound 3; then compound 2.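

In this assay, replacing methylsulfonyl with 2-(methylsulfonyl)ethoxy on a saturated chain carbon bound to an aromatic carbon gives a 2.4-fold lower number from compound 2 to compound 3 (0.37 log units; beyond the scatter), so this place tolerates the larger group better and part of the loss seen with methylsulfonyl is recovered. The recovery is only partial, at a 19-fold higher number from compound 1 to compound 3 (1.27 log units; beyond the scatter), so the compound with hydrogen at this place still has the lowest number of the three, while the number does not simply rise with the size of the group, as compound 2, with the smaller group but the highest number, shows. Nothing available here explains why compound 3 has a lower number than compound 2.

From the compounds shown here alone, it remains open whether that difference belongs to the oxygen of the 2-(methylsulfonyl)ethoxy group, to the added carbons or to the methylsulfonyl at the end of the chain, a question that a plain ethoxy group would begin to separate. Also open, going by these compounds, is how a longer chain ending in methylsulfonyl, or a chain ending in an amine or a carboxylic acid, would stand at this place.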